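Swapping the methylindole for a methoxyphenyl on a shared core

This account rests on a few compounds, and the source may have more. Where it says the series, first, only, none or still open, it means among the compounds named here.

Compound 1, `COc1cc(-c2ccnc3cc(-c4ccc5cc[nH]c5c4)nn23)cc(OC)c1OC`: 187 nM
Compound 2, `COc1cc(-c2ccnc3cc(-c4ccc(C(C)=O)cc4)nn23)cc(OC)c1OC`: 4390 nM
Compound 3, `COc1cc(-c2ccnc3cc(-c4ccc5ccn(C)c5c4)nn23)cc(OC)c1OC`: 1040 nM

All three were measured in a functional assay on HCT-116 cells (Homo sapiens) for inhibition, read by CCK-8 assay, with a stated time of 48 h; on this read-out higher numbers stand for weaker inhibition and lower numbers for stronger inhibition. Compound 3 stands second highest of the three numbers: the step from compound 1 to compound 3 is a 5.6-fold higher number from compound 1 to compound 3 (0.75 log units; beyond the scatter), and the step from compound 2 to compound 3 is a 4.2-fold lower number from compound 2 to compound 3 (0.63 log units; beyond the scatter).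

Compound 4, `COc1ccc(-c2cc3nccc(-c4cc(OC)c(OC)c(OC)c4)n3n2)cc1`, differs from compound 3 by 4-methoxyphenyl in place of 1-methyl-1H-indol-6-yl on an aromatic carbon. Among the measured compounds shown here, the step that bears most on this change is the one from compound 2 to compound 3, where the 4-acetylphenyl group was replaced by the fused 1-methyl-1H-indol-6-yl group and the number fell by a modest step. Compound 4 returns to a single six-membered ring carrying one acceptor, so a modest rise in this assay is expected, a 2.9-fold higher number from compound 3 to compound 4 (0.46 log units; beyond the scatter). Compound 4 is estimated at 3000 nM, with a range from 1000 nM to 9000 nM.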

Compound 4, half-maximal inhibitory concentration: 404 nM
Beside the measured number, compound 4's estimate is 7.4-fold (0.87 log units) above it; the whole stated range lies above it.
By their numbers in this assay, from the lowest: compound 1; then compound 4; then compound 3; then compound 2.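

In this assay, a single six-membered ring at this position can outdo the fused ring of compound 3 (a 2.6-fold lower number from compound 3 to compound 4 (0.41 log units; beyond the scatter)), though the fused, unmethylated indole of compound 1 keeps the lowest number (a 2.2-fold higher number from compound 1 to compound 4 (0.33 log units; beyond the scatter)). Keeping the phenyl ring and changing only its substituent also matters greatly: methoxy in place of acetyl gives a large drop (an 11-fold lower number from compound 2 to compound 4 (1.04 log units; beyond the scatter)). From the compounds shown here alone, whether a hydroxy group, an amine or a longer chain such as ethoxy in place of that methoxy would match compound 1 remains open. Nothing at hand explains why these groups differ.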